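The source may hold more compounds than are shown below. What is called first, only, known or untested is meant among the compounds shown, and "the series" means these compounds.

In a functional assay on MDA-MB-231 cells (Homo sapiens) for antiproliferative activity, read by MTT assay, with a stated time of 48 h (on this read-out lower numbers stand for stronger inhibition and higher numbers for weaker inhibition), compound 1 (`COc1ccc(N(C)c2ccnc(Cl)n2)cc1`) gives 2820 nM, compound 2 (`COc1ccc(N(C)c2ccnc(Cl)n2)cc1[N+](=O)[O-]`) gives 8120 nM, and compound 3 (`COc1ccc(N(C)c2ccnc(Cl)n2)cc1O`) gives 833 nM, the lowest of the three numbers. Compound 4 (`COc1ccc(N(C)c2ccnc(Cl)n2)cc1OCCCBr`) differs from compound 3 by one change: 3-bromopropyl in place of hydrogen on an oxygen on an aromatic ring, which turns hydroxy into 3-bromopropoxy. For the measured compounds named here, two measured steps bear on this change, both introducing the hydroxy: a 3.4-fold lower number from compound 1 to compound 3 (0.53 log units; beyond the scatter) and a 9.7-fold lower number from compound 2 to compound 3 (0.99 log units; beyond the scatter). Neither tests a chain on that oxygen, so the evidence is indirect. Losing the free hydroxy is expected to give back much of the first of these steps, so a modest rise is expected in this assay. The estimated step is a 2.4-fold higher number from compound 3 to compound 4 (0.38 log units; beyond the scatter). Compound 4 is expected at 2000 nM, with an estimated range of 500 nM to 8000 nM.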

Compound 4, half-maximal inhibitory concentration: 1280 nM
The estimate for compound 4 lay 1.6-fold (0.19 log units) above the measured number; measured number inside the range.
By their numbers in this assay, from the lowest: compounds 3 and 4 (each within the scatter of the next); then compound 1; then compound 2.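

In this assay, the free hydroxy hydrogen proves dispensable at this position: putting 3-bromopropyl on the oxygen stays within the scatter (a 1.5-fold higher number from compound 3 to compound 4 (0.19 log units; within the scatter)). The 3-bromopropoxy group also keeps an advantage over both the hydrogen and the nitro group (a 2.2-fold lower number from compound 1 to compound 4 (0.34 log units; beyond the scatter); a 6.3-fold lower number from compound 2 to compound 4 (0.80 log units; beyond the scatter)). Nothing available explains these steps. As far as these compounds go, whether a longer chain, or an amine or a carboxylic acid in place of the bromine, would hold this level remains open.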